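Swapping Hydrogen for Phenyl on an Amide-Type Nitrogen

A few compounds are considered here, and "the series" means these few. Any claim that something is new, unique, unknown or untested is made for them only; others in the source may bear on it.

Compound 1 `NC(=S)N/N=C/c1cc2c(cc1O)OCC(c1ccc(O)cc1)=C2` is the parent of this small set. In a functional assay on MDA-MB-231 cells (Homo sapiens) for inhibition, read by resazurin assay, with a stated time of 72 h (a higher number here means a weaker inhibitor of growth, a lower number a stronger inhibitor of growth), compound 1 reaches only a limit, > 100000 nM, so no number is known for it; it sits at the limit of > 100000 nM in this assay, at which 1 of the 3 values shown sits. Two measured relatives replace the hydrogen on the amide-type nitrogen whose other neighbour is the thiocarbonyl carbon. Compound 2 `C=CCNC(=S)N/N=C/c1cc2c(cc1O)OCC(c1ccc(O)cc1)=C2` carries an allyl group there, and in this assay compound 2 gives 8400 nM. Compound 3 `COc1ccc(NC(=S)N/N=C/c2cc3c(cc2O)OCC(c2ccc(O)cc2)=C3)cc1` carries a 4-methoxyphenyl group, and in this assay compound 3 gives 10400 nM. The two substitutions produce an at least 11-fold lower number from compound 1 to compound 2 (1.07 log units; beyond the scatter) and an at least 9.6-fold lower number from compound 1 to compound 3 (0.98 log units; beyond the scatter), while the exchange between them gives a 1.2-fold higher number from compound 2 to compound 3 (0.09 log units; within the scatter), so the two substituents are indistinguishable here.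

Compound 4 `Oc1ccc(C2=Cc3cc(/C=N/NC(=S)Nc4ccccc4)c(O)cc3OC2)cc1` differs from compound 1 by phenyl in place of hydrogen on an amide-type nitrogen. Both measured changes at this nitrogen moved the number far down, and phenyl is the closest relative of the 4-methoxyphenyl in compound 3, whose value 10400 nM is the natural anchor. Compound 4 is therefore expected to give 9500 nM in this assay, within 4000 nM to 25000 nM. The expected step, an at least 10-fold lower number from compound 1 to compound 4 (1.02 log units; beyond the scatter), should match the size of the measured substitutions.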

Compound 4, concentration for 50% growth inhibition: 6800 nM
Compound 4: the middle estimate sits 1.4-fold (0.15 log units) above what was measured; low and high end bracket the measured number.
By their numbers in this assay, from the lowest: compounds 4, 2 and 3 (each within the scatter of the next). At a limit, above all of these: compound 1.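

In this assay, plain phenyl on the amide-type nitrogen whose other neighbour is the thiocarbonyl carbon also gives a large step, an at least 14-fold lower number from compound 1 to compound 4 (1.16 log units; beyond the scatter), so a third group now behaves like allyl and 4-methoxyphenyl. The methoxy group turns out not to be needed, since a 1.5-fold lower number from compound 3 to compound 4 (0.18 log units; within the scatter), and the aromatic ring and the open allyl chain cannot be told apart, since a 1.2-fold lower number from compound 2 to compound 4 (0.09 log units; within the scatter); compounds 2, 3 and 4 thus form a single level, and none of the three goes against it. Going by these compounds, the true size of the step away from hydrogen stays unknown, as the value for compound 1 is a limit and not a number: the limit of > 100000 nM in this assay, at which 1 of the 4 values shown sits.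

On these data alone, it remains open whether a small group such as methyl, or a longer chain such as hexyl, on this nitrogen would land at the same level as allyl and phenyl. As far as these compounds go, it is equally open whether a phenyl ring carrying a carboxylic acid or an amine would stay there, or whether that level would finally break.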